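Mirror Image of a Cyclopropyl Imidazoline Binder

This account rests on a few compounds, and the source may have more. Where it says the series, first, only, none or still open, it means among the compounds named here.

Of the compounds shown here, three have been measured in an assay on PC-12 cells for binding affinity to Nischarin (Rattus norvegicus); on this read-out higher numbers stand for weaker inhibition and lower numbers for stronger inhibition. Compound 1, `C1CN=C(NC(C2CC2)C2CC2)C1`, gives 513 nM. Compound 2, `COC1=NC(C)(Cl)CC=C1NC1=NCCN1`, gives 33.9 nM. Compound 3, `c1ccc([C@@H]2C[C@H]2C2=NCCN2)cc1`, gives 347 nM. On these numbers compound 3 stands second highest of the three: its value and that of compound 1 lie within the usual scatter of each other, so no order can be read between them, while compound 2 sits beyond the scatter with a clearly lower number.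

Compound 4, `c1ccc([C@H]2C[C@@H]2C2=NCCN2)cc1`, is the mirror image of compound 3: the two compounds have the same atoms and bonds and differ only in configuration as drawn: 2 of 2 stereo elements differ (all stereocentres are inverted: mirror images); a stereocentre at a saturated ring carbon is drawn R in compound 3 and S in compound 4; a stereocentre at a saturated ring carbon is drawn R in compound 3 and S in compound 4. For the measured compounds named here, no pair of measured compounds shows what inverting both stereocentres does, so the size and direction of the step must be guessed. Two mirror images can give the same number or very different ones, and nothing here points either way. The step of a 1.2-fold higher number from compound 3 to compound 4 (0.06 log units; within the scatter) is therefore expected to be small and uncertain, with the range widened to allow for a real difference. For compound 4 the expected value in this assay is 400 nM, with a range from 80 nM to 2500 nM.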

Compound 4, inhibition constant: 11.8 nM
Compound 4: the middle estimate sits 34-fold (1.53 log units) above what was measured; measured number outside the range, below it.
By their numbers in this assay, from the lowest: compound 4; then compound 2; then compounds 3 and 1 (each within the scatter of the next).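

In this assay, inverting both stereocentres gives a 29-fold lower number from compound 3 to compound 4 (1.47 log units; beyond the scatter). This large gap can be traced to configuration alone, with no group entering or leaving, because of a single structural fact: the fact that compounds 3 and 4 differ only in the configuration as drawn. For the compounds shown here, the earlier compounds offered no pair differing in one place, so this is the first readable step, and it shows that two compounds with the same atoms and bonds can sit far apart on this read-out.

Both stereocentres change together here, so the compounds shown cannot tell whether one of them accounts for most of the step or both contribute. Going by these compounds, it also remains open whether the configuration of compound 4 would keep its advantage with a fluorine atom or a hydroxyl group added to the shared core.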